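Bromo to Methyl Swap on Two Different Cores

The source may hold more compounds than are shown below. What is called first, only, known or untested is meant among the compounds shown, and "the series" means these compounds.

Measured compounds:
compound 1 `O=C(/C=C/c1cc(Br)ccc1O)c1ccc(Br)cc1` gives 28.7%
compound 2 `Cc1ccc(C(=O)/C=C/c2cc(Br)ccc2O)cc1` gives 27.3%
compound 3 `COc1cc(Br)cc2c1OC(N)=C(C#N)C2CC(=O)c1ccc(Br)cc1` gives 39.7%

In a functional assay on MCF7 cells (Homo sapiens) for antiproliferative activity, read by sulforhodamine B assay, with a stated time of 72 h, tested at 10 uM (on this read-out lower numbers stand for a stronger effect and higher numbers for a weaker effect at the one concentration tested), compound 1 gives 28.7% and compound 2 gives 27.3%. The change methyl in place of bromo on an aromatic carbon made a number 1.4 percentage points lower from compound 1 to compound 2 (within the scatter). Compound 3 stands at 39.7%, the highest of the three numbers, with its nearest neighbour compound 1 lower and compound 2 further off, both gaps beyond the scatter. The difference between the core of compound 3 and the core of compound 1 is not broken down here.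

Compound 4 `COc1cc(Br)cc2c1OC(N)=C(C#N)C2CC(=O)c1ccc(C)cc1` is not yet measured. It differs from compound 3 by methyl in place of bromo on an aromatic carbon. The place of the change reads the same word for word as the place in the change from compound 1 to compound 2, so this is the same change, now made on the core of compound 3 rather than on the open chalcone.

The expected step is a number 1.7 percentage points lower from compound 3 to compound 4 (within the scatter), because a number 1.4 percentage points lower from compound 1 to compound 2 (within the scatter) lies within the scatter. For compound 4 the estimate is 38%, with a range from 28% to 50%.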

Compound 4, a percentage reported as activity, at one concentration (the size of the read-out at that concentration, not a potency): 116%
Estimate against measurement, compound 4: 78 percentage points below; the measured number lies above the stated range.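

In this assay, methyl in place of bromo gives a number 76.3 percentage points higher from compound 3 to compound 4 (beyond the scatter) and so a far weaker effect at the one concentration tested on this core, with the read-out for compound 4 well beyond that of its bromo partner. This swap therefore does not carry over from the core of compound 1 to the core of compound 3 as a constant step: the same change on two cores in this assay, a number 1.4 percentage points lower (within the scatter) from compound 1 to compound 2 and a number 76.3 percentage points higher (beyond the scatter) from compound 3 to compound 4, 77.7 percentage points apart, beyond the scatter of two such steps

With one pair on each core and a single concentration, these numbers give no potency, do not show which part of the core of compound 3 makes the step so large, and say nothing of a third core.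

It remains open whether the large step on the core of compound 3 follows from the arrival of methyl or the departure of bromo, since no other group at that place is shown. A chloro, an ethyl or a plain hydrogen on that aromatic carbon would separate these two readings.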